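Replacing Diisopropylamino with 2-Aminoethyl in a Series at Its Limit

The source may report more compounds than this note shows. Statements on the series, on what has been measured and on what is new or still open speak of the compounds shown alone.

Values so far in a functional assay on A549 cells (Homo sapiens) for cytotoxicity, read by MTT assay, with stated times of 48 h and 4 h (a lower number here means a stronger inhibitor, a higher number a weaker inhibitor), are limits of the assay and not numbers
- Compound 1 `COc1ccc(/C=C/c2nc(NCCN(C(C)C)C(C)C)c3cc(Cl)ccc3n2)cc1OC` gives > 100000 nM as a limit
- Compound 2 `CC(C)N(CCNc1nc(/C=C/c2ccc([N+](=O)[O-])cc2)nc2ccccc12)C(C)C` gives > 100000 nM as a limit
- Compound 3 `CC(C)N(CCNc1nc(/C=C/c2ccc([N+](=O)[O-])cc2)nc2ccc(Cl)cc12)C(C)C` gives > 100000 nM as a limit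

Compound 3 has no number of its own, only the limit > 100000 nM in this assay as its reading. The whole set sits at the limit of > 100000 nM in this assay, at which 3 of the 3 values shown sit, and none of the compounds can be ranked against another.

The change to compound 4 `NCCCCNc1nc(/C=C/c2ccc([N+](=O)[O-])cc2)nc2ccc(Cl)cc12` is 2-aminoethyl in place of diisopropylamino on a saturated chain carbon, two bonds along the chain from a nitrogen on an aromatic ring and it puts 2-aminoethyl in place of diisopropylamino on a saturated chain carbon, two bonds along the chain from a nitrogen on an aromatic ring. Cut further out, it reads (2-(diisopropylamino)ethyl)amino to (4-aminobutyl)amino.

Two measured steps reach compound 3, namely a step that the two limits leave unreadable from compound 1 to compound 3 and a step that the two limits leave unreadable from compound 2 to compound 3 as the other. Neither has a readable size, and neither touches this chain, so the data offer no size to carry over. A number for compound 4 could only appear on the stronger side of the limit. The estimate is an at least 1.6-fold lower number from compound 3 to compound 4 (0.22 log units; that floor lies within the scatter) in this assay and it is expected to be modest, if it can be read at all. Compound 4 is estimated at 60000 nM with an expected range from 10000 nM to 100000 nM and another limit remains quite possible.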

Compound 4, half-maximal inhibitory concentration: 10000 nM
Compound 4: the middle estimate sits 6.0-fold (0.78 log units) above what was measured; the range from low to high includes it.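

In this assay, for the compounds shown here, the change from (2-(diisopropylamino)ethyl)amino to (4-aminobutyl)amino gives an at least 10-fold lower number from compound 3 to compound 4 (1.00 log units; beyond the scatter), the first step in this set with a readable size. Going by these compounds alone, it shows that this chain is a place where a change can bring a reading off the limit, something the earlier compounds could not show: the steps from compound 1 and compound 2 to compound 3 cannot be read, and neither of them touches this chain. The size of the new step is only a floor, as compound 3 carries a limit and not a number, and compound 4 is the only compound here with a number of its own: the limit of > 100000 nM in this assay, at which 3 of the 4 values shown sit.

The compounds shown leave open whether the lower number goes with the free amine at the end of the 4-aminobutyl chain, with the loss of diisopropylamino, or with the chain itself, and how a dimethylamino group, a morpholine ring or a carboxylic acid at that chain end would read. Also open, going by these compounds, is whether the chloro and 4-nitrophenyl groups affect the reading once this chain is in place, as with 3,4-dimethoxyphenyl in its stead.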